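Sulfonamide to Amide: A Step Into Unmeasured Ground

The source may report more compounds than this note shows. Statements on the series, on what has been measured and on what is new or still open speak of the compounds shown alone.

Measured so far in a functional assay on SK-MEL-28 cells (Homo sapiens) for cytotoxicity, read by MTT assay; a lower number here means a stronger inhibitor, a higher number a weaker inhibitor:
Compound 1, `O=S(=O)(NCCNc1nccc(-c2c(-c3cccc(F)c3)nc3sccn23)n1)c1ccc(Br)cc1`, gives 13500 nM.
Compound 2, `O=S(=O)(NCCNc1nccc(-c2c(-c3cccc(F)c3)nc3sccn23)n1)c1ccc(Cl)cc1`, gives 18600 nM.

Compound 2 stands at the far end of this pair of numbers, but only just: the step of a 1.4-fold higher number from compound 1 to compound 2 (0.14 log units; within the scatter) shows that the two compounds cannot be told apart on these data. Compound 3, `O=C(NCCNc1nccc(-c2c(-c3cccc(F)c3)nc3sccn23)n1)c1ccc(Cl)cc1`, differs from compound 2 by (4-chlorophenyl)carbonyl in place of (4-chlorophenyl)sulfonyl on an amine nitrogen. Among the compounds with values here, the single measured step, from compound 1 to compound 2, swaps one halogen for another on the aromatic ring and leaves the sulfonyl untouched, so it says nothing about exchanging a sulfonyl for a carbonyl. Within the data shown here, no measured step bears directly on this change. Among the measured compounds shown here, with no comparable step at hand, the expectation in this assay is no shift beyond the scatter in either direction, with a wide range to reflect the missing guide. Compound 3 is therefore estimated at 18000 nM, spanning 6000 nM to 55000 nM. That estimate means the step of a 1.0-fold lower number from compound 2 to compound 3 (0.01 log units; within the scatter) is expected to stay small.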

Compound 3, half-maximal inhibitory concentration: 8160 nM
For compound 3 the middle estimate is 2.2-fold (0.34 log units) above the measured one; measured number inside the range.
By their numbers in this assay, from the lowest: compounds 3, 1 and 2 (each within the scatter of the next, the first and the last beyond it).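

In this assay, within the data shown here, putting (4-chlorophenyl)carbonyl in place of (4-chlorophenyl)sulfonyl on the amine nitrogen gives a 2.3-fold lower number from compound 2 to compound 3 (0.36 log units; beyond the scatter) and is the only step here that lies beyond the scatter, so the group on this nitrogen can shift the number in a way that the swap of halogen did not. Set against the bromo compound, the carbonyl compound gives a 1.7-fold lower number from compound 1 to compound 3 (0.22 log units; within the scatter) and cannot be told apart from it, which means that the modest shift is seen against compound 2 only and rests on a single pair of compounds. Nothing available here explains why the carbonyl compound gives the lower number.

The compounds shown leave open whether a similar shift would appear with a different group on this nitrogen, such as a urea or a simple acetyl in place of the (4-chlorophenyl)carbonyl. They also leave open whether the carbonyl series would respond to a bromo or methoxy group on the aromatic ring, or to a longer chain joining the two nitrogens.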